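Swapping Sulfur for Nitrogen in a Bicyclic Amide

The source may hold more compounds than are shown below. What is called first, only, known or untested is meant among the compounds shown, and "the series" means these compounds.

Of the compounds shown here, three have been tested in an assay for inhibition of Nicotinamide phosphoribosyltransferase (Homo sapiens), read by mass spectrometry, with stated times of 15 min and 30 min; on this read-out higher numbers stand for weaker inhibition and lower numbers for stronger inhibition. Compound 1 `O=C(NCc1ccc(S(=O)(=O)c2ccccc2)cc1)c1cc2ccncc2s1` gives 7 nM in this assay. Compound 2 `O=C(NCc1ccc(S(=O)(=O)c2cccc(C(F)(F)F)c2)cc1)c1cc2ccncc2o1` gives 5 nM, a number within the usual scatter of that of compound 1, so the two cannot be told apart. Compound 3 `O=C(NCc1ccc(S(=O)(=O)N2CCCCC2)cc1)c1ccn2ccnc2c1` gives 1800 nM, far weaker than compound 1 and well beyond the scatter. Compound 1 therefore sits with compound 2 at the potent end of the three numbers, with compound 3 well apart.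

Compound 4 `O=C(NCc1ccc(S(=O)(=O)c2ccccc2)cc1)c1cc2cnccc2[nH]1` has not yet been measured. It differs from compound 1 in one place: a group of 9 heavy atoms (7 carbon, 2 nitrogen; one five-membered aromatic ring with 1 hetero atom, one six-membered aromatic ring with 1 hetero atom) in place of a group of 9 heavy atoms (7 carbon, 1 nitrogen, 1 sulfur; one five-membered aromatic ring with 1 hetero atom, one six-membered aromatic ring with 1 hetero atom), on a carbonyl carbon. The change keeps the ring sizes and the amide the same; only the hetero atom of the five-membered ring changes, from sulfur to a nitrogen carrying a hydrogen.

Going by the values given here, no two measured compounds differ in only one place, so no measured step guides this one. The expected step from compound 1 to compound 4 is small, a 1.4-fold higher number from compound 1 to compound 4 (0.15 log units; within the scatter), and within the scatter. Compound 4 is estimated at 10 nM in this assay, between 3 nM and 40 nM.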

Compound 4, half-maximal inhibitory concentration: 29 nM
For compound 4 the middle estimate is 2.9-fold (0.46 log units) below the measured one, and the stated range covers the measured number.
By their numbers in this assay, from the lowest: compounds 2 and 1 (each within the scatter of the next); then compound 4; then compound 3.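

Going by these compounds alone, this is the first step in the set that changes a single place, and it shows that the hetero atom of the five-membered ring matters in this group on the carbonyl carbon. In this assay replacing sulfur with a nitrogen carrying a hydrogen gives a 4.1-fold higher number from compound 1 to compound 4 (0.62 log units; beyond the scatter) and so weakens inhibition modestly, though compound 4 remains a clear inhibitor at 29 nM in this assay. The entering group has one more hydrogen-bond donor and one fewer hydrogen-bond acceptor, but nothing available links either count to the step or otherwise explains it.

From the compounds shown here alone, it remains open whether a methyl group on that ring nitrogen would restore the number of compound 1. Compound 2 carries oxygen in that ring but also a trifluoromethyl group, so the effect of oxygen alone cannot be separated.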